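A few compounds are considered here, and "the series" means these few. Any claim that something is new, unique, unknown or untested is made for them only; others in the source may bear on it.

The compounds described here share one core and were tested in an assay on isolated protein for inhibition of thyroid hormone receptor beta (Homo sapiens), read by fluorescence polarization; on this read-out higher numbers stand for weaker inhibition and lower numbers for stronger inhibition. Compound 1 `Cc1ccc(N2CCN(C(=O)C3CCN(C(=O)c4ccc(S(C)(=O)=O)c([N+](=O)[O-])c4)CC3)CC2)cc1` carries a 4-methylphenyl group at one end of that core. In this assay compound 1 gives > 60000 nM, which is a limit of the assay and not a number. Two further compounds were measured beside it. Compound 2 `CC1CCN(C(=O)CCNC(=O)c2ccc(S(C)(=O)=O)c([N+](=O)[O-])c2)CC1` gives > 60000 nM in this assay, again a limit. Compound 3 `CS(=O)(=O)c1ccc(C(=O)N2CCC(C(=O)N(Cc3ccccc3)c3ccccc3)CC2)cc1[N+](=O)[O-]` gives > 60000 nM in this assay, also a limit. All three values therefore sit at the limit of > 60000 nM in this assay, at which 3 of the 3 values shown sit, so no order among compounds 1, 2 and 3 can be read from them. Compound 4 `CS(=O)(=O)c1ccc(C(=O)N2CCC(C(=O)N3CCN(c4ccccc4)CC3)CC2)cc1[N+](=O)[O-]` has not yet been measured. It differs from compound 1 by hydrogen in place of methyl on an aromatic carbon, so that the 4-methylphenyl group becomes a plain phenyl group. The step of a number no higher from compound 1 to compound 4 (the limit leaves the size open) is expected to be none beyond the usual scatter. Compound 4 is thus expected to give about 60000 nM, within a range from 20000 nM to 200000 nM, most likely reported again only as a limit of the assay.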

Compound 4, half-maximal inhibitory concentration: > 60000 nM
Compound 4: no number, only a limit; the forecaster's own chance of this, stated with the estimate: 90%; the middle value sits exactly at the limit.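

In this assay compound 4 gives > 60000 nM and this is a limit of the assay, not a number. For the compounds shown here, compound 1 also stands only at a limit, so no step between compound 1 and compound 4 can be read: the limit of > 60000 nM in this assay, at which 4 of the 4 values shown sit. The compounds shown leave open which structure around the shared core, if any, would give a true number in this assay.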